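Aryl exchange on the ring nitrogen: a trifluoromethyl variant

The source may hold more compounds than are shown below. What is called first, only, known or untested is meant among the compounds shown, and "the series" means these compounds.

Compound 1 `Nc1scc(CN2CCN(c3ccc(Cl)cc3Cl)CC2)c1C(=O)c1ccc(Cl)cc1` carries a 2,4-dichlorophenyl on an amine nitrogen in a ring. In an assay on CHO cells for displacement of a labelled ligand from adenosine receptor A3 (Homo sapiens), read by scintillation counting, with a stated time of 120 min, tested at 10 uM (on this read-out higher numbers stand for more inhibition at the one concentration tested (going by the name of the read-out) and lower numbers for less inhibition), compound 1 gives 0%. Compound 2 `Nc1scc(CN2CCN(c3cccc(Cl)c3Cl)CC2)c1C(=O)c1ccc(Cl)cc1` gives 0% and compound 3 `Nc1scc(CN2CCN(c3ccc([N+](=O)[O-])cc3)CC2)c1C(=O)c1ccc(Cl)cc1` gives 2%, so compound 1 stands level with compound 2 at the digits shown, the two together being the lowest of the three numbers, with compound 3 the one furthest from it. The step of no change at the digits printed from compound 1 to compound 2 (within the scatter) and the step of a number 2 percentage points higher from compound 1 to compound 3 (within the scatter) both lie within the scatter, as does a number 2 percentage points higher from compound 2 to compound 3 (within the scatter).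

Compound 4 `Nc1scc(CN2CCN(c3cccc(C(F)(F)F)c3)CC2)c1C(=O)c1ccc(Cl)cc1` has not yet been measured. Its change from compound 1 is 3-(trifluoromethyl)phenyl in place of 2,4-dichlorophenyl on an amine nitrogen in a ring. The two measured steps that exchange the same 2,4-dichlorophenyl on that nitrogen were both within the scatter, so from this third exchange no step beyond the scatter is expected in this assay. Compound 4 is therefore estimated to give 1%, with a range from 0% to 10%. That estimate means an expected step of a number 1 percentage points higher from compound 1 to compound 4 (within the scatter).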

Compound 4, a percentage reported as inhibition, at one concentration (the size of the read-out at that concentration, not a potency): 0%
Compound 4: middle estimate off by 1 percentage points, on the high side; the measured number falls inside the stated range.
By their numbers in this assay, from the lowest: compounds 1, 2, 4 and 3 (each within the scatter of the next).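

In this assay, exchanging the aryl group on the amine nitrogen in a ring for 3-(trifluoromethyl)phenyl gives no change at the digits printed from compound 1 to compound 4 (within the scatter) and no change at the digits printed from compound 2 to compound 4 (within the scatter) and also a number 2 percentage points lower from compound 3 to compound 4 (within the scatter). This adds a trifluoromethyl-bearing ring to the chlorine- and nitro-bearing rings, and none of the four compounds goes against the flat picture at this position, with all the steps among them within the scatter. No measurement is available that would explain this flat result.

The compounds leave open whether a phenyl ring carrying an amine or a carboxylic acid, or a longer alkyl chain in place of the aryl group, would change the number on this nitrogen. They also leave open whether any exchange elsewhere on the shared core would do so, since the rest of the core stays the same in all four.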